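A few compounds are considered here, and "the series" means these few. Any claim that something is new, unique, unknown or untested is made for them only; others in the source may bear on it.

Compound 1 `CCCCOc1ccc(C(O)C2OC(=O)c3c(OC)cc(OC)cc32)cc1` — in an ADME assay on RAW264.7 cells (Mus musculus) for cytotoxicity, read by MTT assay, with a stated time of 24 h, in the presence of a further agent that is not named here (a higher number here means a weaker inhibitor, a lower number a stronger inhibitor), compound 1 gives > 40000 nM, a limit of the assay rather than a number.
Compound 2 `COCCOc1ccc(C(O)C2OC(=O)c3c(OC)cc(OC)cc32)cc1` — in this assay compound 2 gives > 40000 nM, likewise a limit.

Within the data shown here, compound 1 therefore stands only at a limit in this assay, and the one further value shown, for compound 2, sits at the same limit (the limit of > 40000 nM in this assay, at which 2 of the 2 values shown sit). The step from compound 1 to compound 2, a step that the two limits leave unreadable from compound 1 to compound 2, cannot be read in size from two limits. Compound 3 `COc1cc(OC)c2c(c1)C(C(O)c1ccc(OCc3ccc(Br)cc3)cc1)OC2=O` differs from compound 1 by 4-bromophenyl in place of propyl on a saturated chain carbon bound to an oxygen on an aromatic ring. Among the measured compounds shown here, no measured step bears on this change: the only recorded step is unreadable and touches a different part of the chain. The step from compound 1 to compound 3 expected in this assay, a step that the limit leaves unreadable from compound 1 to compound 3, thus cannot be given a direction or a size beyond the scatter. Compound 3 is estimated at 60000 nM, with a range from 20000 nM to 200000 nM, and is expected most likely to be reported once more as a limit.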

Compound 3, half-maximal inhibitory concentration: > 40000 nM
Compound 3 gave a limit, no number; the forecaster's own chance of this, stated with the estimate: 70%; the middle value does not contradict the limit.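

Among these compounds, compound 3 stands at a limit, as do compound 1 and compound 2, so no step among the three can be read: the limit of > 40000 nM in this assay, at which 3 of the 3 values shown sit. The compounds shown leave open whether any change at this place would give a number rather than a limit in this assay.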